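The compounds below may be only part of what the source reports. "The series", "measured", "known", "first", "only" and "open" are said of these compounds alone.

Three compounds of this set have been examined in an ADME assay on RAW264.7 cells (Mus musculus) for cytotoxicity, read by MTT assay, with a stated time of 72 h, tested at 50 uM; a higher number here means a stronger effect of the compound at the concentration tested, a lower number a weaker effect. Compound 1 `O=C(Cn1c(=O)oc2cc(Cl)ccc21)NCc1cccs1` gave 20.3%, and compound 2 `O=C(Cn1c(=O)oc2ccccc21)NCc1cccs1` gave 23.4%. These two differ in one place, by chloro in place of hydrogen on an aromatic carbon, and that change produced a number 3.1 percentage points lower from compound 2 to compound 1 (within the scatter). Compound 3 `O=C(Cn1c(=O)oc2ccccc21)Nc1nc2ccc([N+](=O)[O-])cc2s1` shares only the core of compound 2, and how the two cores differ is not broken down here. In this assay compound 3 gave 12.4%, a number within the scatter of compound 1 and beyond the scatter of compound 2.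

Compound 4 `O=C(Cn1c(=O)oc2cc(Cl)ccc21)Nc1nc2ccc([N+](=O)[O-])cc2s1` remains to be measured in this assay. It differs from compound 3 by chloro in place of hydrogen on an aromatic carbon, the same change that separates compound 1 from compound 2, made at the same place. The step from compound 3 to compound 4 is expected to be a number 2.4 percentage points lower from compound 3 to compound 4 (within the scatter), small because a number 3.1 percentage points lower from compound 2 to compound 1 (within the scatter) was itself within the scatter. On that basis compound 4 is estimated to give about 10% in this assay, with a likely range from 2% to 20%.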

Compound 4, a percentage reported as inhibition, at one concentration (the size of the read-out at that concentration, not a potency): 12.5%
For compound 4 the middle estimate is 2.5 percentage points below the measured one; the measured number falls inside the stated range.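

In this assay, chloro in place of hydrogen on an aromatic carbon gave a number 0.1 percentage points higher from compound 3 to compound 4 (within the scatter), so on this second core the change again left the read-out within the scatter. Set side by side, the two steps cannot be told apart: the same change on two cores in this assay, a number 3.1 percentage points lower (within the scatter) from compound 2 to compound 1 and a number 0.1 percentage points higher (within the scatter) from compound 3 to compound 4, 3.2 percentage points apart, within the scatter of two such steps This shows that, for these two pairs, the change carried from one core to the other without a step distinguishable from the scatter; it does not show that the two steps are identical, that the change has no effect at all, or that the same would hold on any further core.

The compounds shown carry only hydrogen or chloro at this place, so it remains open whether a bromo group, a methoxy group, an amine or a carboxylic acid there would move the read-out beyond the scatter. Also open, from the compounds shown here alone, is whether chloro on a different carbon of the same six-membered aromatic ring would behave as it does here.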